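Methoxy to ethoxy on the shared core

The compounds below may be only part of what the source reports. "The series", "measured", "known", "first", "only" and "open" are said of these compounds alone.

Measured so far in a functional assay on HeLa cells (Homo sapiens) for antiproliferative activity, with a stated time of 48 h; a lower number here means a stronger inhibitor, a higher number a weaker inhibitor

Compound 1 `Nc1ccc(/C=C/C(=O)c2ccc(F)cc2)cc1` gives 40000 nM
Compound 2 `Nc1ccc(/C=C/C(=O)c2ccc(Cl)cc2)cc1` gives 43000 nM
Compound 3 `COc1ccc(C(=O)/C=C/c2ccc(N)cc2)cc1` gives 98000 nM

Compound 3 has the highest of the three numbers and is the weakest inhibitor here, with compound 2 nearest (a 2.3-fold higher number from compound 2 to compound 3 (0.36 log units; beyond the scatter)) and compound 1 furthest (a 2.5-fold higher number from compound 1 to compound 3 (0.39 log units; beyond the scatter)). Compounds 1 and 2 do not separate from each other (a 1.1-fold higher number from compound 1 to compound 2 (0.03 log units; within the scatter)).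

Compound 4 `CCOc1ccc(C(=O)/C=C/c2ccc(N)cc2)cc1` has not yet been measured in this assay and differs from compound 3 in one place (methyl in place of hydrogen on a saturated chain carbon bound to an oxygen on an aromatic ring): methyl in place of hydrogen on a saturated chain carbon bound to an oxygen on an aromatic ring, which turns methoxy into ethoxy. Among the measured compounds shown here, no measured step makes this change. The closest evidence is compound 3 itself, reached by two modest steps that bring in the methoxy (a 2.5-fold higher number from compound 1 to compound 3 (0.39 log units; beyond the scatter) and a 2.3-fold higher number from compound 2 to compound 3 (0.36 log units; beyond the scatter)). With only those small steps to go on, no step beyond the scatter is expected in either direction. The estimated step is small (a 1.0-fold higher number from compound 3 to compound 4 (0.01 log units; within the scatter)) and sits within the scatter. Compound 4 is estimated at 100000 nM with 50000 nM to 200000 nM as its expected range.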

Compound 4, half-maximal inhibitory concentration: 41000 nM
The estimate for compound 4 lay 2.4-fold (0.39 log units) above the measured number; the measured number lies below the stated range.
By their numbers in this assay, from the lowest: compounds 1, 4 and 2 (each within the scatter of the next); then compound 3.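

In this assay, adding a single methyl on the saturated chain carbon bound to an oxygen on an aromatic ring, which turns methoxy into ethoxy, gives a modest step beyond the scatter (a 2.4-fold lower number from compound 3 to compound 4 (0.38 log units; beyond the scatter)), so this position responds to a change of one carbon. Among the compounds shown here, the ethoxy group does not separate from either halogen on the aromatic carbon (a 1.0-fold lower number from compound 2 to compound 4 (0.02 log units; within the scatter); a 1.0-fold higher number from compound 1 to compound 4 (0.01 log units; within the scatter)), which leaves compound 3 as the one compound apart from the others and shows, through compound 4, that an oxygen on that aromatic carbon does not by itself go with the higher number. Nothing shown here accounts for this step.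

The compounds shown leave open whether a longer chain such as propoxy, or a branched isopropoxy, would stay level with compound 4 or move the number further, and where a hydroxyl on the same aromatic carbon would fall. They also leave open whether the step from methoxy to ethoxy holds on any core other than the shared one, as it is read here on that core alone.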